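This account rests on a few compounds, and the source may have more. Where it says the series, first, only, none or still open, it means among the compounds named here.

Compound 1 `O=C(O)CCCCC(CCSC(=O)c1ccccc1)SC(=O)c1ccccc1`: 2.76%
Compound 2 `O=C(CCCCC(CCSC(=O)c1ccccc1)SC(=O)c1ccccc1)Nc1ccccc1`: "not active" (no number reported)
Compound 3 `O=C(CCCCC(CCSC(=O)c1ccccc1)SC(=O)c1ccccc1)Nc1ccccc1Cl`: 6.63%

In a functional assay on Bel-7402 cells (Homo sapiens) for inhibition, read by MTT assay, with a stated time of 24 h, tested at 10 ug/mL (on this read-out higher numbers stand for more inhibition of growth at the one concentration tested and lower numbers for less inhibition of growth), compound 3 gives 6.63%, which lies within the scatter of compound 1 at 2.76%. Within the data shown here, compound 2 is reported as "not active" (no number reported), without a number, so it provides no step. Compound 4 `O=C(CCCCC(CCSC(=O)c1ccccc1)SC(=O)c1ccccc1)Nc1cccc(Cl)c1` has not yet been measured. It carries 3-chlorophenyl in place of 2-chlorophenyl on an amide-type nitrogen.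

Among the measured compounds shown here, only one measured step bears on this change, and only indirectly: a number 3.9 percentage points higher from compound 1 to compound 3 (within the scatter). For the measured compounds named here, that step replaces hydroxy with (2-chlorophenyl)amino on a carbonyl carbon, and no measured pair compares 2-chlorophenyl with 3-chlorophenyl directly. Going by the values given here, since the one available step stays within the scatter, no shift beyond the scatter is expected in this assay, and no direction is favoured. The expected change is a number 0.6 percentage points lower from compound 3 to compound 4 (within the scatter). Compound 4 is estimated at 6%, with an expected range of 0% to 15%.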

Compound 4, percent growth inhibition at one concentration: "not active" (no number reported)
Compound 4: no number reported, and the estimate cannot be compared.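

Among these compounds, compound 4 is reported as "not active" without a number, so no step from compound 3 can be read. The compounds shown leave open how far 3-chlorophenyl and 2-chlorophenyl on the amide-type nitrogen differ in growth inhibition. No supporting evidence bears on this result.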